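Hydroxy removal on compound 1, by analogy to compound 2

A few compounds are considered here, and "the series" means these few. Any claim that something is new, unique, unknown or untested is made for them only; others in the source may bear on it.

Compound 1 `Cc1noc(NS(=O)(=O)c2ccc(NC(=O)c3cc4ccc(O)cc4oc3=O)cc2)c1C` and compound 2 `O=C(N/N=C/c1cccnc1)c1cc2ccc(O)cc2oc1=O` share part of their structure, but the difference between the two cores is not broken down here. In a functional assay on CCRF-CEM cells (Homo sapiens) for antiproliferative activity, read by fluorescence and resazurin assay, with a stated time of 48 h (a higher number here means a weaker inhibitor, a lower number a stronger inhibitor), compound 1 gives 21500 nM, and compound 2 gives 14100 nM. Compound 3 `O=C(N/N=C/c1cccnc1)c1cc2ccccc2oc1=O` differs from compound 2 by hydrogen in place of hydroxy on an aromatic carbon; in this assay compound 3 gives 9900 nM, a step of a 1.4-fold lower number from compound 2 to compound 3 (0.15 log units; within the scatter). Compound 4 `Cc1noc(NS(=O)(=O)c2ccc(NC(=O)c3cc4ccccc4oc3=O)cc2)c1C` carries the matching change on compound 1: hydrogen in place of hydroxy on an aromatic carbon. The place descriptions agree word for word, so this is the same kind of change. Compound 4 is not yet measured in this assay. The expected step is a 1.4-fold lower number from compound 1 to compound 4 (0.16 log units; within the scatter) because a 1.4-fold lower number from compound 2 to compound 3 (0.15 log units; within the scatter) lies within the scatter. Compound 4 is therefore estimated at 15000 nM, between 6000 nM and 40000 nM.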

Compound 4, half-maximal inhibitory concentration: 26600 nM
Estimate against measurement, compound 4: 1.8-fold (0.25 log units) below, and the stated range covers the measured number.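

In this assay hydrogen in place of hydroxy on an aromatic carbon gives a 1.2-fold higher number from compound 1 to compound 4 (0.09 log units; within the scatter) and so no change that can be read on the core of compound 1. The two cores agree within what the data can resolve: the same change on two cores in this assay, a 1.4-fold lower number (0.15 log units; within the scatter) from compound 2 to compound 3 and a 1.2-fold higher number (0.09 log units; within the scatter) from compound 1 to compound 4, 1.8-fold (0.25 log units) apart, within the scatter of two such steps.

This supports carrying the change between these two cores only as a step too small to read, and it does not show that any real effect shares its size or direction on both.

Still open, from the compounds shown here alone, is whether a methoxy group or an amine on that aromatic carbon would give a step beyond the scatter on either core. Going by these compounds, whether the same near-silent step holds on a third core also stays open.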